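The compounds below may be only part of what the source reports. "The series", "measured", "known", "first", "only" and "open" are said of these compounds alone.

Compound 1, `Cc1nc2ccc(CN(CC#N)c3ccc(C(=O)N[C@@H](CCC(=O)O)C(=O)O)c(F)c3)cc2c(=O)[nH]1`, holds the second highest of the three numbers in an assay on isolated protein for inhibition of Thymidylate synthase (Mus musculus) (a lower number here means a stronger inhibitor, a higher number a weaker inhibitor), where compound 1 gives 170 nM. Compound 2, `CCN(Cc1ccc2nc(C)[nH]c(=O)c2c1)c1ccc(C(=O)N[C@@H](CCC(=O)O)C(=O)O)c(Cl)c1`, gives 120 nM, which lies within the scatter of compound 1. Compound 3, `CCN(Cc1ccc2nc(C)[nH]c(=O)c2c1)c1ccc(C(=O)N[C@@H](CCC(=O)O)C(=O)O)cc1F`, gives 680 nM, a gap from compound 1 that lies beyond the scatter. Compound 4, `Cc1nc2ccc(CN(CCN)c3ccc(C(=O)N[C@@H](CCC(=O)O)C(=O)O)c(F)c3)cc2c(=O)[nH]1`, differs from compound 1 by aminomethyl in place of cyano on a saturated chain carbon bound to a nitrogen on an aromatic ring, which read one bond further out is cyanomethyl to 2-aminoethyl. No measured pair shows this change, so there is no shown step to lean on. A modest weakening is expected, a 2.4-fold higher number from compound 1 to compound 4 (0.37 log units; beyond the scatter). Compound 4 is estimated at 400 nM, with a range from 100 nM to 1600 nM.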

Compound 4, half-maximal inhibitory concentration: 11700 nM
The estimate for compound 4 lay 29-fold (1.47 log units) below the measured number; the whole stated range lies below it.
By their numbers in this assay, from the lowest: compounds 2 and 1 (each within the scatter of the next); then compound 3; then compound 4.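

In this assay, the group on this chain carbon proves decisive: replacing cyano with aminomethyl gives a 69-fold higher number from compound 1 to compound 4 (1.84 log units; beyond the scatter), a large step for a swap that leaves the heavy-atom count unchanged. At this place, then, the number of heavy atoms alone does not set the result, and the identity of the group matters. Nothing shown accounts for the size of this step. As far as these compounds go, it stays open whether the terminal amine or the loss of the nitrile drives the change; a 2-hydroxyethyl group on the same nitrogen, or an amine on a longer chain, would help separate the two.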